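From 2-fluorophenyl to 4-hydroxyphenyl on the ring nitrogen

The source may report more compounds than this note shows. Statements on the series, on what has been measured and on what is new or still open speak of the compounds shown alone.

Measured compounds in a functional assay on SGC-7901 cells (Homo sapiens) for inhibition, read by MTT assay, with a stated time of 24 h; a lower number here means a stronger inhibitor, a higher number a weaker inhibitor:
compound 1, `Cc1ccc(-n2cc(CN3C(=O)C[C@@H]4CC[C@@]3(C)C4(C)C)nn2)cc1`, compound 1 gives 390 nM
compound 2, `CC1(C)[C@H]2CC[C@]1(C)N(Cc1cn(-c3cccc(Br)c3)nn1)C(=O)C2`, compound 2 gives 120 nM
compound 3, `CC1(C)[C@H]2CC[C@]1(C)N(Cc1cn(-c3ccccc3F)nn1)C(=O)C2`, compound 3 gives 300 nM

Compound 3 stands second highest of the three numbers. Its nearest neighbour is compound 1, and the step of a 1.3-fold lower number from compound 1 to compound 3 (0.11 log units; within the scatter) lies within the scatter, so the two cannot be ordered. Its furthest neighbour is compound 2, and the step of a 2.5-fold higher number from compound 2 to compound 3 (0.40 log units; beyond the scatter) is modest but beyond the scatter.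

Compound 4, `CC1(C)[C@H]2CC[C@]1(C)N(Cc1cn(-c3ccc(O)cc3)nn1)C(=O)C2`, differs from compound 3 in one place: 4-hydroxyphenyl in place of 2-fluorophenyl on an aromatic nitrogen. Within the data shown here, a 4-hydroxyphenyl appears nowhere among the measured compounds, so no step speaks to the hydroxyl directly. Among the measured compounds shown here, the only bearing comes from compound 1, whose 4-methylphenyl sits on the same aromatic nitrogen and whose step a 1.3-fold lower number from compound 1 to compound 3 (0.11 log units; within the scatter) to compound 3 is within the scatter, and from the modest step of a 3.3-fold lower number from compound 1 to compound 2 (0.51 log units; beyond the scatter). The aryl groups tried so far move the number only a little, and compound 4 is therefore expected to stay close to compound 3, with the step of a 1.2-fold higher number from compound 3 to compound 4 (0.07 log units; within the scatter) expected to fall within the scatter. Compound 4 is estimated at 350 nM, in the range 150 nM to 800 nM.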

Compound 4, half-maximal inhibitory concentration: 330 nM
The estimate for compound 4 lay 1.1-fold (0.03 log units) above the measured number; the measured number falls inside the stated range.
By their numbers in this assay, from the lowest: compound 2; then compounds 3, 4 and 1 (each within the scatter of the next).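

In this assay, the 4-hydroxyphenyl group brings a hydrogen-bond donor and a hydrogen-bond acceptor to the aromatic nitrogen, where 2-fluorophenyl has neither, yet the step of a 1.1-fold higher number from compound 3 to compound 4 (0.04 log units; within the scatter) stays within the scatter, so adding them here has no readable effect on the number. The swap of hydroxy for methyl on an aromatic carbon tells the same story: the step of a 1.2-fold lower number from compound 1 to compound 4 (0.07 log units; within the scatter) is also within the scatter, and compounds 1, 3 and 4 cannot be ordered among themselves. Among these compounds, only the modest step of a 2.8-fold higher number from compound 2 to compound 4 (0.44 log units; beyond the scatter) lies beyond the scatter, which leaves the 3-bromophenyl group of compound 2 as the one aryl group of the four that stands apart from the others.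

From the compounds shown here alone, whether a 4-bromophenyl or a 3-hydroxyphenyl group would sit with compound 2 or with the other three remains open, as does what an amine or a carboxylic acid on the same phenyl ring would give. No measurement at hand offers a reason for the lower number of compound 2 or for the closeness of the other three.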